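Swapping the para substituent on a tetrazole amine series

This account rests on a few compounds, and the source may have more. Where it says the series, first, only, none or still open, it means among the compounds named here.

Compound 2 `CNCCN(C)c1nnnn1Cc1ccc(C#N)cc1` carries a cyano group on its benzyl ring. In an assay on cells for inhibition of protein arginine N-methyltransferase 1 (Homo sapiens), read by scintillation counting, with stated times of 15 min and 60 min, tested at 9 uM (on this read-out lower numbers stand for less inhibition and higher numbers for more inhibition at the one concentration tested (going by the name of the read-out)), compound 2 gives 6%. Among the measured compounds shown here, its only measured neighbour is compound 1 `CNCCN(C)c1nnnn1Cc1ccc(OC(F)(F)F)cc1`, which in this assay gives 5%; the two numbers lie within the scatter of each other, so both compounds show little inhibition at this concentration. Compound 3 `CNCCN(C)c1nnnn1Cc1ccc(OC)cc1` is not yet measured. It differs from compound 2 in one place: methoxy in place of cyano on an aromatic carbon. For the measured compounds named here, the one measured step that bears on this position, a number 1 percentage points higher from compound 1 to compound 2 (within the scatter), shows that exchanging one group for another here left the read-out essentially unchanged. With methoxy entering, a similarly flat result is expected, and the step of no change at the digits printed from compound 2 to compound 3 (within the scatter) is estimated to stay within the scatter. Compound 3 is therefore expected to give about 6% in this assay, with a likely range from -4% to 16%.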

Compound 3, a percentage reported as inhibition, at one concentration (the size of the read-out at that concentration, not a potency): 0%
Compound 3: the middle estimate sits 6 percentage points above what was measured, and the stated range covers the measured number.
By their numbers in this assay, from the lowest: compounds 3, 1 and 2 (each within the scatter of the next).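

In this assay, methoxy in place of cyano gives a number 6 percentage points lower from compound 2 to compound 3 (within the scatter), and methyl in place of trifluoromethyl on the oxygen gives a number 5 percentage points lower from compound 1 to compound 3 (within the scatter). A third group on this aromatic carbon therefore joins the earlier exchange in staying within the scatter, and all three compounds show little inhibition at this one concentration. No further data bear on why these groups read alike.

The compounds shown leave open whether any group at this position can lift the read-out clear of the scatter. As far as these compounds go, how a carboxylic acid or an amine on this aromatic carbon, or a longer chain on the oxygen, would read remains unknown, as does whether changes elsewhere on the shared core would matter more.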